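The source may hold more compounds than are shown below. What is called first, only, known or untested is meant among the compounds shown, and "the series" means these compounds.

Three compounds that share one core differ only in the ring attached to a saturated chain carbon bound to a sulfur. Compound 1 `Cc1cc(Nc2cc(-c3ccccc3)[nH]n2)n2nc(SCc3c(Cl)cccc3Cl)nc2n1` carries 2,6-dichlorophenyl there, compound 2 `Cc1cc(Nc2cc(-c3ccccc3)[nH]n2)n2nc(SCc3cccc(Br)c3)nc2n1` carries 3-bromophenyl, and compound 3 `Cc1cc(Nc2cc(-c3ccccc3)[nH]n2)n2nc(SCc3ccc(F)cc3)nc2n1` carries 4-fluorophenyl. In a functional assay on MCF7 cells (Homo sapiens) for inhibition, read by MTT assay, with a stated time of 72 h (on this read-out lower numbers stand for stronger inhibition and higher numbers for weaker inhibition), compound 1 gives 3230 nM, compound 2 gives 5140 nM and compound 3 gives 4020 nM. On these numbers compound 3 holds the second highest of the three, nearest to compound 1 and furthest from compound 2, though every gap stays inside the usual scatter. The three swaps between these rings were all small: a 1.6-fold higher number from compound 1 to compound 2 (0.20 log units; within the scatter), a 1.2-fold higher number from compound 1 to compound 3 (0.10 log units; within the scatter) and a 1.3-fold lower number from compound 2 to compound 3 (0.11 log units; within the scatter).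

Compound 4 `Cc1cc(Nc2cc(-c3ccccc3)[nH]n2)n2nc(SCc3cccc4ccccc34)nc2n1` makes a further change at the same place: naphthalen-1-yl in place of 4-fluorophenyl on a saturated chain carbon bound to a sulfur. All three measured swaps of this ring bear on this step, and none of them moved the number beyond the scatter, so the expected outcome is again a step of no real size in either direction in this assay, expressed as a 1.1-fold lower number from compound 3 to compound 4 (0.02 log units; within the scatter). Compound 4 is therefore estimated at 3800 nM, with an expected range from 1500 nM to 9500 nM. Among the measured compounds shown here, that range is kept wide, since no measured compound carries naphthalen-1-yl or any other group of two six-membered aromatic rings at this place.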

Compound 4, half-maximal inhibitory concentration: 7560 nM
Beside the measured number, compound 4's estimate is 2.0-fold (0.30 log units) below it; the measured number falls inside the stated range.
By their numbers in this assay, from the lowest: compounds 1, 3, 2 and 4 (each within the scatter of the next, the first and the last beyond it).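

In this assay, among the compounds shown here, naphthalen-1-yl, with its 2 six-membered aromatic rings of carbon only, gives the first step at this place on a saturated chain carbon bound to a sulfur that lies beyond the scatter, though only a modest one (a 2.3-fold higher number from compound 1 to compound 4 (0.37 log units; beyond the scatter)). Against the other two rings the same group stays within the scatter (a 1.9-fold higher number from compound 3 to compound 4 (0.27 log units; within the scatter); a 1.5-fold higher number from compound 2 to compound 4 (0.17 log units; within the scatter)), so the one gap that can be read as real is the one to 2,6-dichlorophenyl. The ring at this place can therefore shift the number a little, but across these four compounds the shift remains small, and no clear order can be drawn among most of them.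

Nothing at hand explains why this single gap stands out from the others. Going by these compounds, it also remains open whether the number would move further with something other than an aromatic ring on this carbon, such as an amine, a carboxylic acid or a longer chain, or whether naphthalen-2-yl would behave like naphthalen-1-yl in (this assay).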